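The source may report more compounds than this note shows. Statements on the series, on what has been measured and on what is new or still open speak of the compounds shown alone.

Measured compounds:
- compound 1, `COc1cc(N2C(=O)[C@@H](Oc3ccccc3)[C@H]2c2ccc(Br)cc2)cc(OC)c1OC`: 48000 nM
- compound 2, `COc1cc(N2C(=O)[C@@H](Oc3ccccc3)[C@H]2c2ccc(S(C)(=O)=O)cc2)cc(OC)c1OC`: 62000 nM

In a functional assay on MCF7 cells (Homo sapiens) for antiproliferative activity, read by MTT assay, with stated times of 24 h and 72 h (on this read-out lower numbers stand for stronger inhibition and higher numbers for weaker inhibition), compound 1 gives the lowest of the two numbers, and compound 2 sits close by: a 1.3-fold higher number from compound 1 to compound 2 (0.11 log units; within the scatter). Compound 3, `COc1cc(N2C(=O)[C@@H](Oc3ccccc3)[C@H]2c2cc(O)c(OC)c([N+](=O)[O-])c2)cc(OC)c1OC`, has not been measured. It differs from compound 1 in one place: a group of 12 heavy atoms (7 carbon, 1 nitrogen, 4 oxygen; one six-membered aromatic ring of carbon only) in place of a group of 7 heavy atoms (6 carbon, 1 bromine; one six-membered aromatic ring of carbon only), on a saturated ring carbon. For the measured compounds named here, the only measured step, from compound 1 to compound 2, swaps one small substituent on the aromatic ring and stays within the scatter; it does not involve hydroxy, methoxy or nitro groups, so it says little about the larger replacement leading to compound 3. Going by the values given here, with no direct precedent among the measured compounds, a wide range is expected. Compound 3 is estimated to give 5000 nM in this assay, between 300 nM and 50000 nM, which would be a step of a 9.6-fold lower number from compound 1 to compound 3 (0.98 log units; beyond the scatter) if the expectation holds.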

Compound 3, half-maximal inhibitory concentration: 69000 nM
Compound 3: the middle estimate sits 14-fold (1.14 log units) below what was measured; the whole stated range lies below it.
By their numbers in this assay, from the lowest: compounds 1, 2 and 3 (each within the scatter of the next).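

In this assay there is a 1.4-fold higher number from compound 1 to compound 3 (0.16 log units; within the scatter) when the 4-bromophenyl on the saturated ring carbon gives way to the ring carrying hydroxy, methoxy and nitro groups, and there is a 1.1-fold higher number from compound 2 to compound 3 (0.05 log units; within the scatter) when that same ring replaces the one carrying methylsulfonyl. So far this position had seen only one small swap on the aromatic ring; now a much larger group of 12 heavy atoms also leaves the number within the scatter, so neither the size of this group nor these added substituents produce a readable change here. Nothing measured here accounts for this flat result.

The hydroxy, methoxy and nitro groups enter together, so the part each one plays stays unresolved. From the compounds shown here alone, it also stays open whether an amine or a carboxylic acid on this aromatic ring would move the number at all.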